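The source may report more compounds than this note shows. Statements on the series, on what has been measured and on what is new or still open speak of the compounds shown alone.

Of the compounds shown here, two with a shared core have been measured in an ADME assay on brain (Rattus norvegicus) for protein binding, read by LC-MS, using equilibrium dialysis, with a stated time of 5 h, tested at 5 uM; on this read-out lower numbers stand for a smaller free fraction and higher numbers for a larger free fraction. Compound 1 `C[C@]1(c2cc(NC(=O)c3ccc(C#N)cn3)ccc2F)N=C(N)CO[C@H]1C(F)(F)F` gives 0.03, and compound 2 `COc1cnc(C(=O)Nc2ccc(F)c([C@@]3(C)N=C(N)CO[C@H]3C(F)(F)F)c2)cn1` gives 0.02. Compound 2 thus stands within the scatter of compound 1, and no order can be drawn between them. Compound 3 `COc1cnc(C(=O)Nc2ccc(F)c([C@@]3(C)N=C(N)CO[C@H]3C(F)F)c2)cn1` departs from compound 2 in a single place: hydrogen in place of fluoro on a saturated chain carbon bound to two fluorine atoms and a saturated ring carbon. This puts hydrogen in place of fluoro on a saturated chain carbon bound to two fluorine atoms and a saturated ring carbon, so that trifluoromethyl becomes difluoromethyl. Going by the values given here, the only measured step, a 1.5-fold lower number from compound 1 to compound 2 (0.18 log units; within the scatter), is a different exchange, 5-methoxypyrazin-2-yl in place of 5-cyanopyridin-2-yl on a carbonyl carbon. Among the compounds with values here, it lies within the scatter and does not test the trifluoromethyl group, which no measured pair varies. With no direct evidence, no change beyond the scatter is expected in this assay, and the reading should stay close to that of compound 2, which gives 0.02. The expected step, within the scatter, is a 1.5-fold higher number from compound 2 to compound 3 (0.18 log units; within the scatter). For compound 3 the estimated value is 0.03, with an expected range from 0.015 to 0.06.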

Compound 3, unbound fraction: 0.047
Estimate against measurement, compound 3: 1.6-fold (0.19 log units) below, and the stated range covers the measured number.
By their numbers in this assay, from the lowest: compounds 2, 1 and 3 (each within the scatter of the next, the first and the last beyond it).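

In this assay the step from trifluoromethyl to difluoromethyl is the first change at this position among the compounds shown, and it gives a 2.4-fold higher number from compound 2 to compound 3 (0.37 log units; beyond the scatter) with the rest of the structure held constant. Going by these compounds alone, the one earlier step, made on the carbonyl carbon, stayed within the scatter, so this saturated chain carbon bound to fluorine atoms and a saturated ring carbon is the only place so far where a single exchange moves the unbound fraction beyond the scatter, though the step is modest. No measurement shown accounts for the rise, and the result stands as an observation about this one pair.

Within the data shown here, the exchange is seen only with 5-methoxypyrazin-2-yl on the carbonyl carbon, so whether it carries over to the 5-cyanopyridin-2-yl series remains open. Also open, on these data alone, is whether the number would keep rising along the same line with monofluoromethyl or a plain methyl group on the saturated ring carbon, or whether a longer chain such as ethyl would move it in the same way.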